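The compounds below may be only part of what the source reports. "The series", "measured", "known", "first", "only" and "open" are said of these compounds alone.

In an assay on L1.2 cells for binding affinity to C-C chemokine receptor type 8 (Homo sapiens) (a lower number here means a stronger inhibitor, a higher number a weaker inhibitor), the series begins with compound 1 `CN1CCN(S(=O)(=O)c2ccc(NC(=O)c3ccccc3)c3ccccc23)CC1`. For compound 1 the result is only a limit of the assay, > 30000 nM, as it stands at the limit of > 30000 nM in this assay, at which 1 of the 3 values shown sits. Compound 2 `O=C(Nc1ccc(S(=O)(=O)NC2CCCCC2)c2ccccc12)c1ccccc1` gives 4.4 nM in this assay, and the change from the first to the second is an at least 6800-fold lower number from compound 1 to compound 2 (3.83 log units; beyond the scatter). Compound 3 `CCOC(=O)N1CCC(NS(=O)(=O)c2ccc(NC(=O)c3ccccc3)c3ccccc23)CC1` gives 0.17 nM, and the move from the second to the third is a 26-fold lower number from compound 2 to compound 3 (1.41 log units; beyond the scatter). Compound 3 therefore holds the lowest of the two numbers in this assay, with compound 2 as its nearest neighbour, and the third value being a limit.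

The next step leads to compound 4 `CCOC(=O)N1CCC(NS(=O)(=O)c2ccc(C(=O)NC3CCCCC3)c3ccccc23)CC1`, where (cyclohexylcarbamoyl in place of benzamido on an aromatic carbon). Both measured steps altered the group on the sulfonyl sulfur or the sulfonamide nitrogen and left the benzamido untouched, so neither of them bears directly on this exchange; the size of the two steps shows only that this scaffold responds strongly to changes at its ends. Without a measured precedent at this position, compound 4 is expected to lose some affinity, with a step of an 18-fold higher number from compound 3 to compound 4 (1.25 log units; beyond the scatter) estimated. The estimate for compound 4 in this assay is 3 nM, within a range from 0.3 nM to 50 nM.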

Compound 4, inhibition constant: 9.5 nM
Compound 4: the middle estimate sits 3.2-fold (0.50 log units) below what was measured; the measured number falls inside the stated range.
By their numbers in this assay, from the lowest: compound 3; then compound 2; then compound 4. At a limit, above all of these: compound 1.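

Going by these compounds alone, this is the first measured change at this aromatic carbon, para to a large group, and it shows that the position matters for this assay: the exchange gives a 56-fold higher number from compound 3 to compound 4 (1.75 log units; beyond the scatter), a large step although the leaving and entering groups have the same counts of heavy atoms, hydrogen-bond donors and acceptors. The change is not a single one, since a six-membered aromatic ring gives way to a non-aromatic one and the amide now reaches the core through its carbonyl carbon rather than its nitrogen, so the step belongs to the two together. Nothing measured here accounts for the size of this step.

The compounds shown leave open which of these two differences carries the step, and a phenylcarbamoyl group or a cyclohexanecarboxamido group on the same aromatic carbon would separate them. They also leave open whether other groups here, such as a longer chain between the amide and the ring or an amine on the ring, would move the number in either direction.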